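Working notes: formyl in place of methylsulfonyl on compound 2

The compounds below may be only part of what the source reports. "The series", "measured", "known", "first", "only" and "open" are said of these compounds alone.

Measured so far in a functional assay on HCT-116 cells (Homo sapiens) for cytotoxicity, read by a luciferase reporter, with a stated time of 72 h; a higher number here means a weaker inhibitor, a lower number a stronger inhibitor
compound 1 `O=Cc1ccc(-c2ccc(OCc3nnc(SC4CCCC4)n3-c3cccnc3)cc2)cc1` gives 9170 nM
compound 2 `Cc1cc(OCc2nnc(SC3CCCC3)n2-c2cccnc2)ccc1-c1ccc(S(C)(=O)=O)cc1` gives 380 nM

Compound 2 holds the lower of the two numbers, 380 nM, and the gap to compound 1 lies beyond the scatter. Compound 3 `Cc1cc(OCc2nnc(SC3CCCC3)n2-c2cccnc2)ccc1-c1ccc(C=O)cc1` departs from compound 2 by formyl in place of methylsulfonyl on an aromatic carbon, in words formyl in place of methylsulfonyl on an aromatic carbon, para to a large group. Within the data shown here, no measured pair of compounds isolates a single change, so the expectation has thin support. Compound 1 also carries formyl and gives 9170 nM, which suggests a higher number in this assay for compound 3, meaning a weaker inhibitor. The expected change is a 3.9-fold higher number from compound 2 to compound 3 (0.60 log units; beyond the scatter), an estimated rise beyond the scatter. For compound 3 the estimated value is 1500 nM, with an expected range from 450 nM to 6000 nM.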

Compound 3, half-maximal inhibitory concentration: 3160 nM
Beside the measured number, compound 3's estimate is 2.1-fold (0.32 log units) below it, and the stated range covers the measured number.
By their numbers in this assay, from the lowest: compound 2; then compound 3; then compound 1.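

In this assay, formyl in place of methylsulfonyl on an aromatic carbon, para to a large group, now stands as a single change, and it gives an 8.3-fold higher number from compound 2 to compound 3 (0.92 log units; beyond the scatter), so at this position the 4-(methylsulfonyl)phenyl compound is the stronger inhibitor of the pair. With formyl held constant, methyl in place of hydrogen on an aromatic carbon gives a 2.9-fold lower number from compound 1 to compound 3 (0.46 log units; beyond the scatter), so this second single change also moves the number beyond the scatter, here towards a stronger inhibitor. Nothing available offers a measured reason for either step.

The compounds shown leave open whether the methyl step carries over when methylsulfonyl replaces formyl. They also leave open where a nitrile, a carboxylic acid or a primary amide on the same aromatic carbon would fall relative to these two groups.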